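Chain extension in a chloromethyl ketone series

This account rests on a few compounds, and the source may have more. Where it says the series, first, only, none or still open, it means among the compounds named here.

Compound 1 `CCCCCCCSC[C@H](NC(C)=O)C(=O)CCl` gives 4800 nM in a functional assay on NALM-6 cells (Homo sapiens); on this read-out lower numbers stand for stronger inhibition and higher numbers for weaker inhibition. Compound 2 `CCCCCCCCSC[C@H](NC(C)=O)C(=O)CCl` carries methyl in place of hydrogen on a saturated chain carbon, seven bonds along the chain from a sulfur and gives 5600 nM; the step of a 1.2-fold higher number from compound 1 to compound 2 (0.07 log units; within the scatter) lies within the scatter. Compound 3 `CCCCCCCCCCCCSC[C@H](NC(C)=O)C(=O)CCl` differs from compound 1 by pentyl in place of hydrogen on a saturated chain carbon, seven bonds along the chain from a sulfur. In this assay compound 3 gives 2000 nM, the lowest number of the three, with steps a 2.4-fold lower number from compound 1 to compound 3 (0.38 log units; beyond the scatter) and a 2.8-fold lower number from compound 2 to compound 3 (0.45 log units; beyond the scatter) both beyond the scatter. Compound 4 `CCCCCCCCCCCCCSC[C@H](NC(C)=O)C(=O)CCl`, not yet measured, differs from compound 3 by methyl in place of hydrogen on a saturated chain carbon, ten or more bonds along the chain from a sulfur. This is the same kind of change as that from compound 1 to compound 2, though at a different place along the chain. Because the earlier step of a 1.2-fold higher number from compound 1 to compound 2 (0.07 log units; within the scatter) stayed within the scatter, the step from compound 3 to compound 4 is expected to be small, about a 1.1-fold lower number from compound 3 to compound 4 (0.05 log units; within the scatter). Compound 4 is therefore estimated at 1800 nM in this assay, between 900 nM and 3600 nM.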

Compound 4, half-maximal inhibitory concentration: > 100000 nM
Compound 4: a limit, no number (the forecaster's own chance of this, stated with the estimate: 5%); at least 55-fold (1.74 log units) between middle value and limit.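

In this assay compound 4 gives > 100000 nM, a limit of the assay and not a number. Adding methyl does not carry over from the core of compound 1 to the core of compound 3, and the result is a large step in each comparison, with an at least 50-fold higher number from compound 3 to compound 4 (1.69 log units; beyond the scatter), an at least 17-fold higher number from compound 2 to compound 4 (1.25 log units; beyond the scatter) and an at least 20-fold higher number from compound 1 to compound 4 (1.31 log units; beyond the scatter); the two methyl steps differ: the same change on two cores in this assay, a 1.2-fold higher number (0.07 log units; within the scatter) from compound 1 to compound 2 and an at least 50-fold higher number (1.69 log units; beyond the scatter) from compound 3 to compound 4, at least 42-fold (1.63 log units) apart, beyond the scatter of two such steps. This shows that the outcome of this change depends on the core in this series, but not how large the loss truly is, nor whether it would recur on any other chain.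

Still open, going by these compounds, is whether a longer chain stays at the limit. Also open, on these data alone, is whether a chain ending in an amine or a carboxylic acid behaves like compound 3 or compound 4.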